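The source may hold more compounds than are shown below. What is called first, only, known or untested is meant among the compounds shown, and "the series" means these compounds.

Compound 1 `COc1ccccc1/C=C/C(=O)c1ccc(OC)c2c1OC(C)(C)C=C2`: > 10000 nM
Compound 2 `COc1ccc(C(=O)/C=C/c2cccc(O)c2)c2c1C=CC(C)(C)O2`: > 10000 nM

In a functional assay on SK-OV-3 cells (Homo sapiens) for antiproliferative activity, read by MTT assay, with a stated time of 24 h (on this read-out higher numbers stand for weaker inhibition and lower numbers for stronger inhibition), compound 1 gives > 10000 nM, which is a limit and not a number. From the compounds shown here alone, compound 2 gives > 10000 nM, again only a limit, so its true position is unknown. Compound 3 `COc1ccc(C(=O)/C=C/c2cc(Cl)ccc2O)c2c1C=CC(C)(C)O2` keeps the shared core and changes one group: 5-chloro-2-hydroxyphenyl in place of 3-hydroxyphenyl on a double-bonded chain carbon bound to a double-bonded chain carbon. For the measured compounds named here, the only measured change at this place is a step that the two limits leave unreadable from compound 1 to compound 2. It offers no size to carry over, and both measured compounds stand at the limit of > 10000 nM in this assay, at which 2 of the 2 values shown sit. No firm direction can therefore be expected in this assay, and the likeliest outcome is another limit. The expected step is a step that the limit leaves unreadable from compound 2 to compound 3, and this remains a rough estimate. For compound 3 the estimated value is 15000 nM, with an expected range from 5000 nM to 40000 nM.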

Compound 3, half-maximal inhibitory concentration: 6270 nM
For compound 3 the middle estimate is 2.4-fold (0.38 log units) above the measured one; measured number inside the range.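

At this place, on a double-bonded chain carbon bound to a double-bonded chain carbon, 5-chloro-2-hydroxyphenyl is the only group shown that gives a number rather than a limit in this assay, with compound 3 at 6270 nM. The change gives an at least 1.5-fold lower number from compound 2 to compound 3 (0.20 log units; that floor lies within the scatter), and the comparison with the 2-methoxyphenyl group gives an at least 1.5-fold lower number from compound 1 to compound 3 (0.20 log units; that floor lies within the scatter). Both are floors whose true size stays unknown, and the step between the other two compounds still cannot be read: the limit of > 10000 nM in this assay, at which 2 of the 3 values shown sit.

The compounds shown leave open whether the chlorine alone or the changed placing of the hydroxy group goes with the number for compound 3. Also open, from the compounds shown here alone, is how a phenyl carrying an amine or a carboxylic acid would read at this place in this assay.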